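The source may hold more compounds than are shown below. What is called first, only, known or untested is meant among the compounds shown, and "the series" means these compounds.

In a functional assay on A549 cells (Homo sapiens) for antiproliferative activity, read by MTT assay, with a stated time of 48 h (on this read-out higher numbers stand for weaker inhibition and lower numbers for stronger inhibition), compound 1 (`C/C(=C\CC/C(C)=C/CC[C@@H]1[C@@]2(C)CCC(=O)C(C)(C)[C@H]2CC[C@@]1(C)O)CC/C=C(\C)C(=O)OCc1cn(-c2ccc(C(F)(F)F)cc2)nn1`) gives > 150000 nM as a limit of the assay and not a number. Compound 2 (`C/C(=C\CC/C(C)=C/CC[C@@H]1[C@@]2(C)CCC(=O)C(C)(C)[C@H]2CC[C@@]1(C)O)CC/C=C(\C)C(=O)OCc1cn(-c2ccccc2Cl)nn1`) gives > 150000 nM as a limit too, so it has no number of its own. For the measured compounds named here, the one measured step is a step that the two limits leave unreadable from compound 1 to compound 2 and it swaps the group on the same aromatic nitrogen that changes next. Compound 3 (`C/C(=C\CC/C(C)=C/CC[C@@H]1[C@@]2(C)CCC(=O)C(C)(C)[C@H]2CC[C@@]1(C)O)CC/C=C(\C)C(=O)OCc1cn(-c2ccc(C)cc2)nn1`) carries 4-methylphenyl in place of 2-chlorophenyl on that nitrogen (4-methylphenyl in place of 2-chlorophenyl on an aromatic nitrogen) and the rest of the molecule stays the same. The evidence so far (the limit of > 150000 nM in this assay, at which 2 of the 2 values shown sit) gives no step size to carry over. No step beyond the scatter is therefore expected in this assay and the estimated step is a number no higher from compound 2 to compound 3 (the limit leaves the size open) with no clear direction. Compound 3 is estimated at 150000 nM (range 60000 nM to 300000 nM) and it may well be reported only as a limit.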

Compound 3, half-maximal inhibitory concentration: > 150000 nM
Compound 3 ended at the assay's limit (the forecaster's own chance of this, stated with the estimate: 75%); the middle value lies on the limit itself.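

No step can be read between compound 1, compound 2 and compound 3, since each result is a limit of the assay and not a number: the limit of > 150000 nM in this assay, at which 3 of the 3 values shown sit.

The compounds shown leave open how strongly any of them acts in this assay, and whether the group on the aromatic nitrogen matters at all.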